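Swapping the amide aryl group on a potent pyridinyl analogue

A few compounds are considered here, and "the series" means these few. Any claim that something is new, unique, unknown or untested is made for them only; others in the source may bear on it.

The compounds measured so far, with their results in a functional assay on MDA-MB-231 cells (Homo sapiens) for cytotoxicity, read by MTT assay, with a stated time of 72 h; a higher number here means a weaker inhibitor, a lower number a stronger inhibitor:
compound 1, `O=C(CN1CCN(c2nnc(Cc3ccncc3)c3ccccc23)CC1)Nc1cccc(F)c1`: 4.4 nM
compound 2, `Cc1ccccc1NC(=O)CN1CCN(c2nnc(Cc3ccccc3)c3ccccc23)CC1`: 17300 nM
compound 3, `O=C(CN1CCN(c2nnc(Cc3ccccc3)c3ccccc23)CC1)Nc1cccc(F)c1`: 3730 nM

Compound 1 gives the lowest number of the three in this assay, and its gaps to the other two are both well beyond the scatter: there is an 850-fold higher number from compound 1 to compound 3 (2.93 log units; beyond the scatter), and compound 2 sits further away still. Compound 4, `Cc1cccc(Cl)c1NC(=O)CN1CCN(c2nnc(Cc3ccncc3)c3ccccc23)CC1`, keeps the pyridin-4-yl group and the shared core of compound 1 and changes only the aryl group on the amide. 2-chloro-6-methylphenyl in place of 3-fluorophenyl on an amide-type nitrogen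

Within the data shown here, one measured step touches the same position: a 4.6-fold lower number from compound 2 to compound 3 (0.67 log units; beyond the scatter). That step, though, was read in the phenyl series rather than the pyridinyl series, and it compared a single methyl against a single fluorine, so it only loosely anticipates a chlorine and a methyl together. The large step from compound 1 to compound 3 concerns the other end of the molecule and suggests that the pyridinyl group, retained in compound 4, carries most of the potency. A modest rise in this assay is therefore expected for compound 4, of about a 4.5-fold higher number from compound 1 to compound 4 (0.66 log units; beyond the scatter). Compound 4 is estimated at 20 nM, within a range of 4 nM to 120 nM.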

Compound 4, half-maximal inhibitory concentration: 2670 nM
Compound 4: middle estimate off by 130-fold (2.13 log units), on the low side; measured number above the stated range.
By their numbers in this assay, from the lowest: compound 1; then compounds 4 and 3 (each within the scatter of the next); then compound 2.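

In this assay, with the pyridin-4-yl group and the shared core held fixed, putting 2-chloro-6-methylphenyl in place of 3-fluorophenyl on the amide nitrogen gives a 610-fold higher number from compound 1 to compound 4 (2.78 log units; beyond the scatter), so the aryl group on the amide also decides the result in this series, and far more than the modest 4.6-fold lower number from compound 2 to compound 3 (0.67 log units; beyond the scatter) for a different pair of groups in the phenyl series had hinted. The pyridin-4-yl group alone therefore does not secure a low number, although an 850-fold higher number from compound 1 to compound 3 (2.93 log units; beyond the scatter) could have suggested that it does: of these compounds, only compound 1, which pairs pyridin-4-yl with 3-fluorophenyl, reaches 4.4 nM in this assay. Nothing available here explains why this swap on the amide nitrogen has so large an effect.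

The single change combines a new chlorine, a new methyl and the loss of the fluorine, so the compounds shown leave open which of these drives the step. With the pyridin-4-yl group kept, an unsubstituted phenyl or a cyclohexyl group on the amide nitrogen would show how much of the low number depends on the 3-fluorophenyl group itself.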